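The source may hold more compounds than are shown below. What is called first, only, known or untested is meant among the compounds shown, and "the series" means these compounds.

Working notes on the series in a functional assay (aorta) with Rattus norvegicus as the target; on this read-out higher numbers stand for an effect only at larger amounts of compound and lower numbers for an effect already at smaller amounts.

Of the compounds shown here, two have numbers so far. Compound 1 `COc1ccc(-c2nc(CNC(=O)c3cccnc3)sc2-c2ccc(OC)cc2)cc1` gives 8.2 uM in this assay. Compound 2 `CNC(=O)NCc1nc(-c2ccc(OC)cc2)c(-c2ccc(OC)cc2)s1` gives 15 uM in this assay. Going by the values given here, the only single-point step between them, methylamino in place of pyridin-3-yl on a carbonyl carbon, is a 1.8-fold higher number from compound 1 to compound 2 (0.26 log units; within the scatter), so the two compounds cannot be set in order. Compound 2 holds the higher of the two numbers, with compound 1 nearest to it, and the gap between them is within the scatter.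

Compound 3 `COc1ccc(-c2nc(/C=C/C(=O)O)sc2-c2ccc(OC)cc2)cc1` has not been measured in this assay. It differs from compound 2 as follows: 2-carboxyethenyl in place of ((methylcarbamoyl)amino)methyl on an aromatic carbon. Among the compounds with values here, none of the measured steps bears on this change. Within the data shown here, the one step in hand, from compound 1 to compound 2, exchanges a group on a carbonyl carbon while keeping the methylene and the amide linkage; here the whole side chain is replaced. Among the measured compounds shown here, with no comparable step available, no direction can be read from the data, and the expectation is set near compound 2 with a wide range. The step from compound 2 to compound 3 is expected at no change at the digits printed from compound 2 to compound 3 (within the scatter). Compound 3 is estimated at 15 uM, in the range from 3 uM to 70 uM.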

Compound 3, concentration for half-maximal effect: 55 uM
For compound 3 the middle estimate is 3.7-fold (0.56 log units) below the measured one; the measured number falls inside the stated range.
By their numbers in this assay, from the lowest: compounds 1 and 2 (each within the scatter of the next); then compound 3.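

Going by these compounds alone, the step from the pair to compound 3 is the first to lie beyond the scatter in this assay. Placing 2-carboxyethenyl on the aromatic carbon next to the ring nitrogen and next to the ring sulfur gives a 3.7-fold higher number from compound 2 to compound 3 (0.56 log units; beyond the scatter) in place of ((methylcarbamoyl)amino)methyl, and a 6.7-fold higher number from compound 1 to compound 3 (0.83 log units; beyond the scatter) in place of (((pyridin-3-yl)carbonyl)amino)methyl. The position is therefore not indifferent to its side chain: exchanging the whole chain moves the read-out towards effects only at larger amounts of compound, from either starting point, whereas the exchange at the far end of the chain stayed within the scatter, and nothing in hand accounts for this shift.

Each of these steps replaces the linking atoms and the end group together, so the compounds shown do not separate the contribution of the carboxylic acid from that of the ethenyl link. A saturated propanoic acid chain, a methyl ester of the same chain, or a simple amine on a methylene at this carbon would each bear on that question.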